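This account rests on a few compounds, and the source may have more. Where it says the series, first, only, none or still open, it means among the compounds named here.

Three compounds share a pattern in which an amide links a substituted aromatic acid to a protected amino acid bearing a sulfur-containing side chain. Compound 1 `C#CCSC[C@H](NC(=O)c1cc(OC)c(OC)c(OC)c1)C(=O)OC` carries a propargylsulfanyl side chain on a core with three methyl ethers, and compound 2 `COC(=O)[C@H](CSCc1ccccc1)NC(=O)c1cc(OC)c(OC)c(OC)c1` differs from it only by phenyl in place of ethynyl on a saturated chain carbon bound to a sulfur. In an assay on RAW264.7 cells for antagonist activity at Toll-like receptor 2 (Mus musculus), read by Griess assay, with a stated time of 24 h (on this read-out lower numbers stand for stronger inhibition and higher numbers for weaker inhibition), compound 1 gives 53200 nM, and compound 2 gives 32700 nM; the step of a 1.6-fold lower number from compound 1 to compound 2 (0.21 log units; within the scatter) is small. Compound 3 `C#CCSC[C@H](NC(=O)c1cc(O)c(O)c(O)c1)C(=O)OC` keeps the propargylsulfanyl side chain but has a core with free hydroxyls; the difference between its core and the core of compound 1 is not broken down here. In this assay compound 3 gives 71500 nM. Compound 4 `COC(=O)[C@H](CSCc1ccccc1)NC(=O)c1cc(O)c(O)c(O)c1` is built from compound 3 by the same change, (phenyl in place of ethynyl on a saturated chain carbon bound to a sulfur), at the same place. Because the earlier step of a 1.6-fold lower number from compound 1 to compound 2 (0.21 log units; within the scatter) stayed within the scatter, a similarly modest step a 1.6-fold lower number from compound 3 to compound 4 (0.20 log units; within the scatter) is expected here. Compound 4 is therefore estimated at 45000 nM, with a range from 22000 nM to 90000 nM.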

Compound 4, half-maximal inhibitory concentration: 60700 nM
Compound 4: the middle estimate sits 1.3-fold (0.13 log units) below what was measured; the range from low to high includes it.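

In this assay, putting phenyl in place of ethynyl on the core with free hydroxyls gives a 1.2-fold lower number from compound 3 to compound 4 (0.07 log units; within the scatter), so the change again stays within the usual scatter. Set beside the step on the core of compound 1, the change looks alike on both cores: the same change on two cores in this assay, a 1.6-fold lower number (0.21 log units; within the scatter) from compound 1 to compound 2 and a 1.2-fold lower number (0.07 log units; within the scatter) from compound 3 to compound 4, 1.4-fold (0.14 log units) apart, within the scatter of two such steps. This shows that the change stayed small on these two cores, but with both steps inside the scatter it does not show that the change has any real effect on inhibition, and two cores cannot say how it would behave on a third.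

The compounds shown leave open whether a different group at this place on the side chain, such as an amine or a carboxylic acid, would move the number beyond the scatter. They also leave open what would happen if a carboxylic acid stood in place of the methyl ester that all four compounds share.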